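Aryl Swap on Compound 1 Assessed for Cell Cytotoxicity

The source may hold more compounds than are shown below. What is called first, only, known or untested is meant among the compounds shown, and "the series" means these compounds.

Compound 1, `O=C(CSc1nnc(-c2ccncc2)o1)N/N=C/c1ccc(O)cc1`: 5510 nM in a functional assay on HepG2 cells (Homo sapiens) for cytotoxicity, read by MTT assay, with a stated time of 48 h; on this read-out higher numbers stand for weaker inhibition and lower numbers for stronger inhibition
Compound 2, `O=C(CSc1nnc(-c2ccncc2)o1)N/N=C/c1cccc(F)c1`: 19500 nM
Compound 3, `O=C(CSc1nnc(-c2ccncc2)o1)N/N=C/c1ccccc1F`: 16000 nM

Compound 1 holds the lowest number of the three, the other two lying at a 2.9-fold higher number from compound 1 to compound 3 (0.46 log units; beyond the scatter) and a 3.5-fold higher number from compound 1 to compound 2 (0.55 log units; beyond the scatter). The two fluorinated analogues sit together, with a 1.2-fold lower number from compound 2 to compound 3 (0.09 log units; within the scatter). Compound 4, `O=C(CSc1nnc(-c2ccncc2)o1)N/N=C/c1cc(Cl)cc(Cl)c1O`, is derived from compound 1 by 3,5-dichloro-2-hydroxyphenyl in place of 4-hydroxyphenyl on a carbon with a double bond to nitrogen. For the measured compounds named here, the steps that bear on this change are a 3.5-fold higher number from compound 1 to compound 2 (0.55 log units; beyond the scatter) and a 2.9-fold higher number from compound 1 to compound 3 (0.46 log units; beyond the scatter); both removed the 4-hydroxyphenyl and both raised the number modestly. Going by the values given here, no measured step introduces chlorine. Since compound 4 keeps a hydroxyl group, a shift no larger than those is expected, a 1.2-fold lower number from compound 1 to compound 4 (0.09 log units; within the scatter). Compound 4 is therefore estimated at 4500 nM, with a range from 1500 nM to 14000 nM.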

Compound 4, half-maximal inhibitory concentration: 3260 nM
Beside the measured number, compound 4's estimate is 1.4-fold (0.14 log units) above it; the measured number falls inside the stated range.
By their numbers in this assay, from the lowest: compounds 4 and 1 (each within the scatter of the next); then compounds 3 and 2 (each within the scatter of the next).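

In this assay, the carbon with a double bond to nitrogen accepts 3,5-dichloro-2-hydroxyphenyl in place of 4-hydroxyphenyl with a step that stays within the scatter, a 1.7-fold lower number from compound 1 to compound 4 (0.23 log units; within the scatter). Against the fluorinated analogues the same group stands apart, with a 4.9-fold lower number from compound 3 to compound 4 (0.69 log units; beyond the scatter) and a 6.0-fold lower number from compound 2 to compound 4 (0.78 log units; beyond the scatter), so the two aryl groups carrying a hydroxyl lie together at the low end of these four compounds. No measurement shown here accounts for this difference. The compounds shown leave open whether the chlorines or the hydroxyl group set this level, and how an aryl group bearing an amine or a carboxylic acid would read at this place.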